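The compounds below may be only part of what the source reports. "The series", "measured", "known", "first", "only" and "open" are said of these compounds alone.

Working notes on the series. In a functional assay on HT-29 cells (Homo sapiens) for antiproliferative activity, read by MTT assay, with a stated time of 72 h (on this read-out lower numbers stand for stronger inhibition and higher numbers for weaker inhibition), compound 1 `CCCCn1ccnc1-c1cc(OC)c(OC)c(OC)c1` gives > 100000 nM, which is a limit and not a number. Compound 2 `COc1cc(-c2nccn2S(=O)(=O)c2ccc(C)cc2)cc(OC)c1OC` gives > 100000 nM, also a limit. Compound 1 therefore sits at the limit of > 100000 nM in this assay, at which 2 of the 3 values shown sit. Compound 3 `COc1ccc(-n2ccnc2-c2cc(OC)c(OC)c(OC)c2)cc1[N+](=O)[O-]`, with a six-membered aromatic ring of carbon only on the same nitrogen, gives a measured 600 nM.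

Compound 4 `COc1cc(-c2nccn2-c2cccc(C)c2)cc(OC)c1OC` has 3-methylphenyl in place of butyl on an aromatic nitrogen. Going by the values given here, no measured pair isolates this change. Among the compounds with values here, compound 3 at 600 nM is the only guide, so a large step toward stronger inhibition is expected in this assay. The estimated step is an at least 40-fold lower number from compound 1 to compound 4 (1.60 log units; beyond the scatter). For compound 4 the expected value is 2500 nM, with an estimated range of 150 nM to 40000 nM.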

Compound 4, half-maximal inhibitory concentration: 14600 nM
Estimate against measurement, compound 4: 5.8-fold (0.77 log units) below; the measured number falls inside the stated range.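

In this assay 3-methylphenyl in place of butyl on this aromatic nitrogen gives an at least 6.8-fold lower number from compound 1 to compound 4 (0.83 log units; beyond the scatter) and so brings a value that can be read as a number. A six-membered aromatic ring of carbon only therefore moves compound 4 off the limit without any nitro or methoxy group on that ring. Compound 1 holds only a limit, so the step gives a floor and not a full size: the limit of > 100000 nM in this assay, at which 2 of the 4 values shown sit.

From the compounds shown here alone, how far the place of the methyl on this ring matters stays open. So does how an amine or a carboxylic acid on the ring, or a longer chain in place of butyl, would read.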